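Changing the sulfonyl aryl group of compound 2

The compounds below may be only part of what the source reports. "The series", "measured", "known", "first", "only" and "open" are said of these compounds alone.

For the measured compounds named here, in a functional assay on A549 cells (Homo sapiens) for antiproliferative activity, read by MTT assay, with a stated time of 24 h (a higher number here means a weaker inhibitor, a lower number a stronger inhibitor), compound 1 (`Cc1ccc(C)c(S(=O)(=O)n2c(-c3cn(-c4ccccc4)nc3-c3ccc(F)cc3)nc3ccccc32)c1`) gives 200 nM and compound 2 (`Cc1ccc(C)c(S(=O)(=O)n2c(-c3cn(-c4ccccc4)nc3-c3ccc(C(F)(F)F)cc3)nc3ccccc32)c1`) gives 150 nM as its reading, so compound 2 stands level with the only other compound measured. Going by the values given here, the single measured step, a 1.3-fold lower number from compound 1 to compound 2 (0.12 log units; within the scatter) for trifluoromethyl in place of fluoro on an aromatic carbon, is no larger than the usual spread of repeat measurements.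

Compound 3 (`O=S(=O)(c1ccc(C(F)(F)F)cc1)n1c(-c2cn(-c3ccccc3)nc2-c2ccc(C(F)(F)F)cc2)nc2ccccc21`) differs from compound 2 elsewhere, with 4-(trifluoromethyl)phenyl in place of 2,5-dimethylphenyl on a sulfonyl sulfur. Among the compounds with values here, no measured step touches this group, so that one small step offers only weak guidance, and no clear direction can be argued. The expected outcome is a 1.2-fold higher number from compound 2 to compound 3 (0.08 log units; within the scatter) in this assay as a working estimate, with no shift beyond the scatter anticipated. For compound 3 the estimated value is 180 nM with an expected range from 60 nM to 550 nM before measurement.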

Compound 3, half-maximal inhibitory concentration: 860 nM
Estimate against measurement, compound 3: 4.8-fold (0.68 log units) below; the measured number lies above the stated range.
By their numbers in this assay, from the lowest: compounds 2 and 1 (each within the scatter of the next); then compound 3.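

Putting 4-(trifluoromethyl)phenyl in place of 2,5-dimethylphenyl on the sulfonyl sulfur gives a 5.7-fold higher number from compound 2 to compound 3 (0.76 log units; beyond the scatter) in this assay and makes compound 3 the weaker inhibitor of the pair. This is the first step shown that goes beyond the scatter, so the aryl group on the sulfonyl sulfur matters in a way that the fluoro-to-trifluoromethyl change on the aromatic carbon did not show. No measurement here explains why the number rises.

From the compounds shown here alone, the change removes two methyl groups and adds a trifluoromethyl group at once, so it remains open which of these drives the step. A plain phenyl on the sulfonyl sulfur could help separate the two, and how an amine on that ring would read is also an open question.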